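Diethylamino to 4-methylpiperidinyl swap in an antiproliferative series

A few compounds are considered here, and "the series" means these few. Any claim that something is new, unique, unknown or untested is made for them only; others in the source may bear on it.

Measured compounds:
compound 1 `CCN(CC)Cc1ccc(NC(=O)N/N=C(\C)c2ccccn2)cc1`, in a functional assay on MCF7 cells (Homo sapiens) for antiproliferative activity, read by CCK-8 assay, with a stated time of 24 h (a lower number here means a stronger inhibitor, a higher number a weaker inhibitor), compound 1 gives > 40000 nM
compound 2 `CCN(CC)Cc1ccc(NC(=O)NN=C(c2ccccn2)c2ccccn2)cc1`, in this assay compound 2 gives > 40000 nM
compound 3 `C/C(=N\NC(=O)Nc1ccc(CN2CCC(C)CC2)cc1)c1ccccn1`, in this assay compound 3 gives > 40000 nM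

Each of these three values is a limit of the assay and not a number. All three sit at the limit of > 40000 nM in this assay, at which 3 of the 3 values shown sit.

From compound 1 to compound 3 the change is 4-methylpiperidin-1-yl in place of diethylamino on a saturated chain carbon bound to an aromatic carbon. The step it made, a step that the two limits leave unreadable from compound 1 to compound 3, cannot be sized because both ends sit at the limit of > 40000 nM in this assay, at which 3 of the 3 values shown sit.

Compound 4 `CC1CCN(Cc2ccc(NC(=O)NN=C(c3ccccn3)c3ccccn3)cc2)CC1` is not yet measured. It differs from compound 2 by 4-methylpiperidin-1-yl in place of diethylamino on a saturated chain carbon bound to an aromatic carbon, the same change in the same place as from compound 1 to compound 3. How the core of compound 2 differs from that of compound 1 is not broken down here.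

Given that compound 1 and compound 3 both stay at the limit of > 40000 nM in this assay, at which 3 of the 3 values shown sit, the step from compound 2 to compound 4 is expected to be flat, a step that the limit leaves unreadable from compound 2 to compound 4. Compound 4 is therefore estimated at 60000 nM, most likely reported as a limit again, between 40000 nM and 200000 nM.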

Compound 4, half-maximal inhibitory concentration: > 40000 nM
Compound 4: only a limit was reported (the forecaster's own chance of this, stated with the estimate: 85%); the middle value is on the limit's open side.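

In this assay compound 4 gives > 40000 nM, a limit of the assay and not a number. The change from compound 2 to compound 4 cannot be sized, because both ends sit at the same limit: the limit of > 40000 nM in this assay, at which 4 of the 4 values shown sit. As far as these compounds go, what 4-methylpiperidin-1-yl in place of diethylamino does to activity on either core stays open, as does any ranking of the four compounds.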